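Pyrimidin-2-yl in Place of 4-Chlorophenyl on the Ring Nitrogen

The source may hold more compounds than are shown below. What is called first, only, known or untested is meant among the compounds shown, and "the series" means these compounds.

Compound 1, `Nc1ccccc1NC(=O)c1ccc(CSC(=S)N2CCN(c3ccc(Cl)cc3)CC2)cc1`: 29%
Compound 2, `Nc1ccccc1NC(=O)c1ccc(CSC(=S)N2CCc3cc([N+](=O)[O-])ccc32)cc1`: 29.5%

Of the compounds shown here, two have been tested in a functional assay on A-375 cells (Homo sapiens) for antiproliferative activity, read by CCK-8 assay, with a stated time of 72 h, tested at 8 uM; a lower number here means a weaker effect, a higher number a stronger effect of the compound at the concentration tested. Compound 1 gives 29% there, and compound 2 gives 29.5%. The two numbers lie within the scatter of each other, so compound 1 stands on the same footing as compound 2 rather than apart from it; neither can be called the stronger.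

Compound 3, `Nc1ccccc1NC(=O)c1ccc(CSC(=S)N2CCN(c3ncccn3)CC2)cc1`, remains unmeasured. It differs from compound 1 in one place: pyrimidin-2-yl in place of 4-chlorophenyl on an amine nitrogen in a ring. Among the compounds with values here, no measured pair shows what such a change does here, so nothing in the data fixes a direction. Within the data shown here, since compound 1 gives 29% and the only comparison on hand is flat, the step is expected to be a number 2 percentage points lower from compound 1 to compound 3 (within the scatter), that is, none beyond the scatter. Compound 3 is accordingly estimated at 27%, with a range from 12% to 42%.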

Compound 3, a percentage reported as inhibition, at one concentration (the size of the read-out at that concentration, not a potency): 67.9%
Compound 3: the middle estimate sits 40.9 percentage points below what was measured, outside the stated range (above it).
By their numbers in this assay, from the lowest: compounds 1 and 2 (each within the scatter of the next); then compound 3.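

The group on the amine nitrogen in a ring proves to matter strongly in this assay: putting pyrimidin-2-yl in place of 4-chlorophenyl gives a number 38.9 percentage points higher from compound 1 to compound 3 (beyond the scatter), a large step from exchanging one six-membered aromatic ring for another. The group that leaves has a ring of carbon only and 0 hydrogen-bond acceptors, while the group that enters has a ring with 2 hetero atoms and 2 hydrogen-bond acceptors, and the rest of the structure stays the same. No measurement at hand explains the size of this step.

Going by these compounds, it remains open whether the step requires both ring nitrogens of pyrimidin-2-yl, which a pyridin-2-yl group at the same place would help to settle. On these data alone, it is also open whether an unsubstituted phenyl would stay with the chlorinated ring or move towards the pyrimidine.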